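The source may report more compounds than this note shows. Statements on the series, on what has been measured and on what is new or still open speak of the compounds shown alone.

Series notes, in vivo inhibition of the forebrain enzyme.

Among the measured compounds shown here, compound 1 `C=C=CCN(C)Cc1ccccc1` is the first member. In an assay on forebrain for inhibition of Monoamine oxidase (Mus musculus) (on this read-out lower numbers stand for an effect already at smaller amounts and higher numbers for an effect only at larger amounts of compound), compound 1 gives only a limit, > 48 umol/kg, and no number.

For the measured compounds named here, compound 2 `C=C=C(Cc1ccccc1)CN(C)C` is the second member, and the only compound for which this assay returns a number: compound 2 gives 72 umol/kg. Among the values shown, compound 2 therefore stands alone as a measured dose, the other entry being the limit described in the limit of > 48 umol/kg in this assay, at which 1 of the 2 values shown sits. Going by the values given here, no step between two measured compounds is available, so there is no measured precedent for the size of any structural change.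

Compound 3 `C=C=C(CN)Cc1ccccc1` is not yet measured. It differs from compound 2 by amino in place of dimethylamino on a saturated chain carbon bound to a double-bonded chain carbon; amino in place of dimethylamino on a saturated chain carbon bound to a double-bonded chain carbon. Among the compounds with values here, with no measured step to lean on, the change is expected to produce a modest shift toward an effect at smaller amounts, a 1.8-fold lower number from compound 2 to compound 3 (0.26 log units; within the scatter), though a result within the usual scatter would not surprise. Compound 3 is accordingly estimated at 40 umol/kg in this assay, within a range from 10 umol/kg to 150 umol/kg.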

Compound 3, dose for half-maximal effect: > 26 umol/kg
Compound 3 ended at the assay's limit; the forecaster's own chance of this, stated with the estimate: 15%; the middle value lies beyond the limit too.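

In this assay compound 3 gives only a limit of > 26 umol/kg and no number, so the step from compound 2 to compound 3 cannot be read. The compounds shown leave open whether amino in place of dimethylamino on this saturated chain carbon shifts the dose for half-maximal effect at all, and in which direction.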